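Dichlorophenyl variant of a bis-benzylidene scaffold

This account rests on a few compounds, and the source may have more. Where it says the series, first, only, none or still open, it means among the compounds named here.

Compound 1 `C=CCn1c(=O)/c(=C\c2ccccc2F)[nH]c(=O)/c1=C\c1ccccc1OC`: 18500 nM
Compound 2 `C=CCn1c(=O)/c(=C\c2ccc(C)cc2)[nH]c(=O)/c1=C\c1ccccc1OC`: "not active" (no number reported)
Compound 3 `C=CCn1c(=O)/c(=C\c2ccccc2Cl)[nH]c(=O)/c1=C\c1ccccc1OC`: 4200 nM

In a functional assay on HL-60 cells (Homo sapiens) for cytotoxicity, read by CCK-8 assay, with a stated time of 72 h (on this read-out higher numbers stand for weaker inhibition and lower numbers for stronger inhibition), compound 3 gives the lowest of the two numbers; compound 2 gave "not active" (no number reported) without a number. Going by the values given here, the one measured step, a 4.4-fold lower number from compound 1 to compound 3 (0.64 log units; beyond the scatter), is modest. Compound 4 `C=CCn1c(=O)/c(=C\c2ccc(Cl)c(Cl)c2)[nH]c(=O)/c1=C\c1ccccc1OC` carries 3,4-dichlorophenyl in place of 2-chlorophenyl on a double-bonded chain carbon bound to an aromatic carbon. Among the compounds with values here, no measured step covers this change directly; the outcome for compound 2 warns that not every aromatic substitution pattern keeps activity. Compound 4 is expected to land near compound 3, with a step of a 1.4-fold higher number from compound 3 to compound 4 (0.15 log units; within the scatter) in this assay, within or just beyond the scatter. Compound 4 is therefore estimated at 6000 nM, ranging from 1500 nM to 30000 nM.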

Compound 4, half-maximal inhibitory concentration: "not active" (no number reported)
Compound 4 has no reported number here, and the estimate cannot be compared.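

Going by these compounds alone, compound 4, like compound 2, gave no number in this assay so no step from compound 3 to compound 4 can be read. No evidence shown bears on this result. The compounds shown leave open which other substitution patterns on this phenyl ring give a number.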